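A few compounds are considered here, and "the series" means these few. Any claim that something is new, unique, unknown or untested is made for them only; others in the source may bear on it.

Series notes, oral tail flick.

Compound 2 `CC(C)C[C@H](NC(=O)CN(c1ncnc2c1ncn2C1CCCCO1)C1CC1)C(=O)OCc1ccccc1` in a functional assay on the whole organism (Tail, strain ICR) with Mus musculus as the target, in the tail flick test, with a stated time of 120 min, at a dose of 25 umol/kg by the oral route (a higher number here means a stronger effect of the compound at the dose given, a lower number a weaker effect), gives 12.8%. Compound 1 `NC(=O)CC[C@H](NC(=O)CN(c1ncnc2c1ncn2C1CCCCO1)C1CC1)C(=O)OCc1ccccc1` differs from compound 2 by carbamoylmethyl in place of isopropyl on a saturated chain carbon, two bonds along the chain from an amide-type nitrogen and a carbonyl carbon, and compound 1 gives 22.3%. The step is a number 9.5 percentage points higher from compound 2 to compound 1 (within the scatter).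

Compound 3 `CC(C)C[C@H](NC(=O)CN(c1nc(Cl)nc2[nH]cnc12)C1CC1)C(=O)O` carries a different core; the difference between the core of compound 3 and the core of compound 2 is not broken down here. In this assay compound 3 gives 18.7%. Compared with compound 1, compound 3 sits a few points lower, and compared with compound 2 a few points higher, both gaps within the scatter, so no order among compounds 1, 2 and 3 can be read from these three numbers.

Compound 4 `NC(=O)CC[C@H](NC(=O)CN(c1nc(Cl)nc2[nH]cnc12)C1CC1)C(=O)O` is not yet measured. It differs from compound 3 by carbamoylmethyl in place of isopropyl on a saturated chain carbon, two bonds along the chain from an amide-type nitrogen and a carbonyl carbon, the same change as from compound 2 to compound 1. Among the compounds with values here, for compound 4 in this assay a step of about a number 6.3 percentage points higher from compound 3 to compound 4 (within the scatter) is expected, resting on the single earlier instance of this change, a number 9.5 percentage points higher from compound 2 to compound 1 (within the scatter), which stayed within the scatter. Compound 4 is therefore estimated at 25%, between 12% and 38%.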

Compound 4, a percentage reported as activity, at one dose (the size of the read-out at that dose, not a potency): 17.8%
Beside the measured number, compound 4's estimate is 7.2 percentage points above it; measured number inside the range.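

In this assay, carbamoylmethyl in place of isopropyl on the saturated chain carbon now gives a number 0.9 percentage points lower from compound 3 to compound 4 (within the scatter), and the two instances of this change compare as follows: the same change on two cores in this assay, a number 9.5 percentage points higher (within the scatter) from compound 2 to compound 1 and a number 0.9 percentage points lower (within the scatter) from compound 3 to compound 4, 10.4 percentage points apart, within the scatter of two such steps

The two cores thus give no sign of responding differently to this change, and neither step separates the two compounds of its pair. This does not show that the change carries over from one core to another with a fixed size: two steps within the scatter fit a change with no effect as well as a small effect that differs between the cores.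

Open, on these data alone, is whether an amine or a carboxylic acid in place of carbamoylmethyl on this chain carbon, or a longer chain there, would give a step beyond the scatter in this assay on either core. The read-out gives the size of the effect at a single dose and a single time only, and whether any of these compounds would show a stronger or weaker effect at another dose or time also stays open.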